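The compounds below may be only part of what the source reports. "The series", "measured", "known", "first", "only" and "open" are said of these compounds alone.

Measured compounds:
Compound 1 `Cc1nc(C(NC(=O)C(=O)Nc2ccc(F)c(F)c2)C2CCCCN2)sc1CO`: in an ADME assay on TZM-b1 cells (Homo sapiens) for cytotoxicity, read by XTT assay, with a stated time of 3 days (a lower number here means that less compound is tolerated, a higher number that more compound is tolerated), compound 1 gives > 87000 nM, a limit of the assay.
Compound 2 `Cc1nc(C(NC(=O)C(=O)Nc2ccc(F)cc2F)C2CCCCN2)sc1CO`: in this assay compound 2 gives > 87000 nM, a limit of the assay.
Compound 3 `Cc1nc(C(NC(=O)C(=O)Nc2ccc(Cl)cc2)C2CCCCN2C)sc1CCO`: in this assay compound 3 gives 36000 nM.

Compound 2 stands at the limit of this assay, with no numerical value of its own. For the measured compounds named here, the one step that touches it, a step that the two limits leave unreadable from compound 1 to compound 2, cannot be read because both ends sit at the limit of > 87000 nM in this assay, at which 2 of the 3 values shown sit. Compound 4 `Cc1nc(C(NC(=O)C(=O)Nc2ccc(Cl)cc2)C2CCCCN2)sc1CO` differs from compound 2 by 4-chlorophenyl in place of 2,4-difluorophenyl on an amide-type nitrogen. Going by the values given here, no measured step bears directly on this change, so its size is open. Compound 3 carries the same 4-chlorophenyl group on the amide-type nitrogen but differs from compound 4 at other places as well, and it returns a number rather than a limit. The expected step is an at least 1.0-fold lower number from compound 2 to compound 4 (0.03 log units; that floor lies within the scatter), with no clear direction and nothing beyond the scatter claimed. In this assay compound 4 is estimated at 80000 nM, between 30000 nM and 200000 nM, most likely again reported as a limit.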

Compound 4, half-maximal cytotoxic concentration: > 22000 nM
Compound 4 was reported as a limit; the forecaster's own chance of this, stated with the estimate: 60%; the middle value does not contradict the limit.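

No new step can be read in this assay: compound 4, like compound 1 and compound 2, stands at a limit of the assay. The compounds shown leave open whether 4-chlorophenyl in place of 2,4-difluorophenyl or 3,4-difluorophenyl on the amide-type nitrogen shifts the tolerated concentration at all.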